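The compounds below may be only part of what the source reports. "The series", "measured", "known", "first", "only" and "open" are said of these compounds alone.

Three compounds share one core and differ only in the group attached through an oxygen on a saturated carbon. Compound 1 `Cc1cccc(C(=O)OC2CCC(CN3CCN(c4cc(=O)c5cc(C(F)(F)F)cc([N+](=O)[O-])c5s4)CC3)CC2)c1` carries a (3-methylphenyl)carbonyl there, compound 2 `CS(=O)(=O)OC1CCC(CN2CCN(c3cc(=O)c4cc(C(F)(F)F)cc([N+](=O)[O-])c4s3)CC2)CC1` a methylsulfonyl, and compound 3 `O=C(OC1CCC(CN2CCN(c3cc(=O)c4cc(C(F)(F)F)cc([N+](=O)[O-])c4s3)CC2)CC1)c1ccc2c(c1)OCC2` another carbonyl-linked group. In an ADME assay on Vero cells (Chlorocebus sabaeus) for cytotoxicity, read by MTT assay, with a stated time of 48 h (on this read-out higher numbers stand for weaker inhibition and lower numbers for stronger inhibition), compound 1 gives > 64 ug/mL, which is a limit of the assay and not a number. In this assay compound 2 gives > 64 ug/mL, again a limit rather than a number. Compound 3 gives > 64 ug/mL in this assay, also a limit. Compound 2 thus stands where the others stand, at the limit of > 64 ug/mL in this assay, at which 3 of the 3 values shown sit. The steps a step that the two limits leave unreadable from compound 1 to compound 2, a step that the two limits leave unreadable from compound 1 to compound 3 and a step that the two limits leave unreadable from compound 2 to compound 3 therefore cannot be sized.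

Compound 4 `O=c1cc(N2CCN(CC3CCC(OS(=O)(=O)c4ccc5c(c4)CCO5)CC3)CC2)sc2c([N+](=O)[O-])cc(C(F)(F)F)cc12` has not been measured. Compared with compound 2, the change is a group of 9 heavy atoms (8 carbon, 1 oxygen; one five-membered non-aromatic ring with 1 hetero atom, one six-membered aromatic ring of carbon only) in place of one carbon atom, on a sulfonyl sulfur. Going by the values given here, no measured step bears readably on this change; every exchange of the group on that oxygen left the value at the limit. The step that the limit leaves unreadable from compound 2 to compound 4 is therefore expected to be none beyond the scatter, most likely ending again at the limit. Compound 4 is estimated at 80 ug/mL, with a range from 40 ug/mL to 200 ug/mL.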

Compound 4, half-maximal inhibitory concentration: > 64 ug/mL
Compound 4 gave a limit, no number (the forecaster's own chance of this, stated with the estimate: 85%); the middle value is on the limit's open side.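

In this assay compound 4 gives > 64 ug/mL, a limit and not a number, so its steps from compound 1, compound 2 and compound 3 cannot be read: the limit of > 64 ug/mL in this assay, at which 4 of the 4 values shown sit. As far as these compounds go, whether these four compounds differ at all in this assay stays open, since none has a true number.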